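Chain extension from compound 2 to compound 3

The compounds below may be only part of what the source reports. "The series", "measured", "known", "first", "only" and "open" are said of these compounds alone.

- compound 1 `CCCCCCCCCCCCCCCCn1cc(COC[C@@H]2OC[C@H](N)[C@@H]2O)nn1` gives 20000 nM in the series
- compound 2 `CCCCCCCCCCCCn1cc(COC[C@@H]2OC[C@H](N)[C@H]2O)nn1` gives 93800 nM in the series

Both values come from a functional assay on EC9706 cells (Homo sapiens) for antiproliferative activity, read by MTT assay, with a stated time of 48 h; a higher number here means a weaker inhibitor, a lower number a stronger inhibitor. Compound 2 has the higher of the two numbers, beyond the scatter of compound 1, and so is the weaker inhibitor of the pair. Compound 3 `CCCCCCCCCCCCCCCCn1cc(COC[C@@H]2OC[C@H](N)[C@H]2O)nn1` is still to be measured. The change from compound 2 is butyl in place of hydrogen on a saturated chain carbon, ten or more bonds along the chain from an aromatic nitrogen. Among the measured compounds shown here, no measured pair isolates this change, and the two measured compounds differ in more than one place. The chain of compound 3 also occurs in compound 1, which reads 20000 nM, so a moderate move toward a lower number in this assay is expected. The estimated size is a 3.1-fold lower number from compound 2 to compound 3 (0.50 log units; beyond the scatter), a step expected to lie beyond the scatter. Compound 3 is estimated at 30000 nM (expected range 12000 nM to 70000 nM).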

Compound 3, half-maximal inhibitory concentration: 6310 nM
Compound 3: middle estimate off by 4.8-fold (0.68 log units), on the high side; the whole stated range lies above it.
By their numbers in this assay, from the lowest: compound 3; then compound 1; then compound 2.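

In this assay, among the compounds shown here, butyl in place of hydrogen on a saturated chain carbon, ten or more bonds along the chain from an aromatic nitrogen, gives a 15-fold lower number from compound 2 to compound 3 (1.17 log units; beyond the scatter), a large step and the first reading of this chain change on its own. With the chain held constant, the stereocentre at a saturated ring carbon, drawn S in compound 1 and R in compound 3, also matters, with a modest step: a 3.2-fold lower number from compound 1 to compound 3 (0.50 log units; beyond the scatter). The earlier pair mixed chain and configuration, whereas this pair isolates configuration: the fact that compounds 1 and 3 differ only in the configuration as drawn

On these data alone, whether the gain from butyl continues with a longer chain remains open, as does the effect of the same stereocentre change on the shorter chain of compound 2. As far as these compounds go, the effect of an acetamide in place of the free amine on the shared core is also open.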